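The source may report more compounds than this note shows. Statements on the series, on what has been measured and on what is new or still open speak of the compounds shown alone.

Three compounds that share one core have been examined in a functional assay on the whole organism for positive allosteric modulation, with Rattus norvegicus as the target; a higher number here means that more compound is needed for the effect, a lower number that less compound is needed. Compound 1 `Cc1nn(C)c2c1C(c1cccc(Cl)c1)=NCCN2` carries a chloro group on its aromatic ring, and in this assay compound 1 gives 0.63 mg/kg. Compound 2 `Cc1nn(C)c2c1C(c1cccc(C(F)(F)F)c1)=NCCN2` carries a trifluoromethyl group in its place, and in this assay compound 2 gives 0.63 mg/kg. Compound 3 `Cc1nn(C)c2c1C(c1cccc(Br)c1)=NCCN2` carries a bromo group, and in this assay compound 3 gives 0.63 mg/kg. The steps between them are no change at the digits printed from compound 1 to compound 2 (within the scatter), no change at the digits printed from compound 1 to compound 3 (within the scatter) and no change at the digits printed from compound 2 to compound 3 (within the scatter), so compound 3 stands level with compounds 1 and 2 in this assay. Compound 4 `Cc1nn(C)c2c1C(c1cccc(F)c1)=NCCN2` differs from compound 3 in one place: fluoro in place of bromo on an aromatic carbon. All three measured steps bear on this change, since each exchanges one group on an aromatic carbon of the same ring, and none of them moved this assay beyond the scatter. Compound 4 is therefore expected to show a step of no change at the digits printed from compound 3 to compound 4 (within the scatter) in this assay, that is, none beyond the scatter. Compound 4 is estimated at 0.63 mg/kg, with a range from 0.32 mg/kg to 1.3 mg/kg.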

Compound 4, minimum effective dose: 2.5 mg/kg
For compound 4 the middle estimate is 4.0-fold (0.60 log units) below the measured one, and the stated range ends below it.
By their numbers in this assay, from the lowest: compounds 1, 2 and 3 (each within the scatter of the next); then compound 4.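

In this assay this place on the aromatic ring proves not to be indifferent to its group: the exchange of bromo for fluoro gives a 4.0-fold higher number from compound 3 to compound 4 (0.60 log units; beyond the scatter) and the exchange of trifluoromethyl for fluoro gives a 4.0-fold higher number from compound 2 to compound 4 (0.60 log units; beyond the scatter) while the exchange of chloro for fluoro gives a 4.0-fold higher number from compound 1 to compound 4 (0.60 log units; beyond the scatter) on the same carbon. The level values of compounds 1, 2 and 3 therefore do not extend to every group at this place, and among the four compounds fluoro alone stands apart. Nothing shown here accounts for this difference.

From the compounds shown here alone, it remains open whether a hydrogen, a methyl or a methoxy group at this place would stand level with compounds 1, 2 and 3 or with compound 4. A nitrile or an amine at the same carbon is equally unresolved.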